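A few compounds are considered here, and "the series" means these few. Any claim that something is new, unique, unknown or untested is made for them only; others in the source may bear on it.

Measured compounds:
compound 1 `CC(C)c1ccc(N2C(=O)C=CC2OCC(F)(F)F)cc1`: 5800 nM in a functional assay on HeLa cells (Homo sapiens) for inhibition; on this read-out higher numbers stand for weaker inhibition and lower numbers for stronger inhibition
compound 2 `O=C1C=CC(OCC(F)(F)F)N1c1cc(Cl)cc(Cl)c1`: 5920 nM in this assay
compound 3 `O=C1C=CC(OCC(F)(F)F)N1c1ccc(Cl)cc1F`: 8320 nM in this assay

Going by the values given here, compound 1 stands within the scatter of compound 2 and of compound 3; the three numbers do not separate from one another, and no measured pair in this set differs in a single place, so there is no measured step to lean on. Compound 4 `O=C1C=CC(OCC(F)(F)F)N1c1ccc(C(F)(F)F)cc1` differs from compound 1 by trifluoromethyl in place of isopropyl on an aromatic carbon. Among the compounds with values here, nothing among the measured compounds shows what such a change does, so no direction is favoured; in this assay the expected step of a 1.1-fold higher number from compound 1 to compound 4 (0.05 log units; within the scatter) is small and should stay within the scatter. Compound 4 is therefore estimated at 6500 nM, with an expected range from 2500 nM to 17000 nM.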

Compound 4, half-maximal inhibitory concentration: 36200 nM
Compound 4: middle estimate off by 5.6-fold (0.75 log units), on the low side; measured number above the stated range.
By their numbers in this assay, from the lowest: compounds 1, 2 and 3 (each within the scatter of the next); then compound 4.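

In this assay, the place on the aromatic carbon para to a large group proves sensitive to what it carries: trifluoromethyl in place of isopropyl gives a 6.2-fold higher number from compound 1 to compound 4 (0.80 log units; beyond the scatter) and so weaker inhibition. Going by these compounds alone, this is the only single-place step so far, and the first evidence that a change at this place can move the number beyond the scatter. Nothing available explains the step.

One step gives no trend across groups at this place. From the compounds shown here alone, how a tert-butyl group, a nitrile or an amine would read there remains open.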